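Chloro-indole acid series: methyl step to compound 3

The source may hold more compounds than are shown below. What is called first, only, known or untested is meant among the compounds shown, and "the series" means these compounds.

Measured so far in an assay on HeLa cells for displacement of a labelled ligand from thyroid hormone receptor beta (Homo sapiens); on this read-out higher numbers stand for weaker inhibition and lower numbers for stronger inhibition:
compound 1 `CC(C)c1cc(Cn2ccc3cc(OCC(=O)O)ccc32)ccc1O`: 1.04 nM
compound 2 `CC(C)c1cc(Cn2ccc3cc(OCC(=O)O)cc(Cl)c32)ccc1O`: 0.07 nM

Compound 2 gives the lowest of the two numbers; the nearest is compound 1, separated by a 15-fold lower number from compound 1 to compound 2 (1.17 log units; beyond the scatter). That step is the only one measured and it concerns a different change, so nothing measured bears directly on the move to compound 3 `Cc1cn(Cc2ccc(O)c(C(C)C)c2)c2c(Cl)cc(OCC(=O)O)cc12`, which carries methyl in place of hydrogen on an aromatic carbon. Among the measured compounds shown here, with no comparable step available, the expectation for compound 3 is a change within the scatter, no change at the digits printed from compound 2 to compound 3 (within the scatter), giving an estimate of 0.07 nM with a range of 0.02 nM to 0.25 nM in this assay.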

Compound 3, inhibition constant: 0.09 nM
For compound 3 the middle estimate is 1.3-fold (0.11 log units) below the measured one, and the stated range covers the measured number.
By their numbers in this assay, from the lowest: compounds 2 and 3 (each within the scatter of the next); then compound 1.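

In this assay the methyl in place of hydrogen gives a 1.3-fold higher number from compound 2 to compound 3 (0.11 log units; within the scatter), so the potency gained with chloro in compound 2 is kept in compound 3. Among the compounds shown here, this is the first reading at this position, on the five-membered aromatic ring two ring bonds from the ring nitrogen, and it shows that one added carbon there is accepted. No evidence bears on this result.

Open, on these data alone, is whether an ethyl group, a longer chain or an amine at this position would also stay within the scatter. Also open, as far as these compounds go, is whether methyl gives the same result on the core of compound 1, which has hydrogen in place of chloro.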